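Toward a Dichlorophenyl Hydrazone on the Shared Core

The compounds below may be only part of what the source reports. "The series", "measured", "known", "first", "only" and "open" are said of these compounds alone.

Of the compounds shown here, three built on one shared core have been measured in a functional assay on HOP-92 cells (Homo sapiens) for inhibition, read by sulforhodamine B assay, with a stated time of 48 h; a higher number here means a weaker inhibitor of growth, a lower number a stronger inhibitor of growth. Compound 1 `O=C(Cc1csc2nc(-c3ccc(Br)cc3)cn12)N/N=C/c1ccccc1` gives 12300 nM. Compound 2 `O=C(Cc1csc2nc(-c3ccc(Br)cc3)cn12)N/N=C/c1ccccc1O` gives 2090 nM, and the step of a 5.9-fold lower number from compound 1 to compound 2 (0.77 log units; beyond the scatter) stands beyond the scatter. Compound 3 `COc1cccc(OC)c1/C=N/NC(=O)Cc1csc2nc(-c3ccc(Br)cc3)cn12` gives 13800 nM, the highest of the three numbers, although a 1.1-fold higher number from compound 1 to compound 3 (0.05 log units; within the scatter) lies within the scatter; only a 6.6-fold higher number from compound 2 to compound 3 (0.82 log units; beyond the scatter) separates compound 3 clearly from another compound.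

Compound 4 `O=C(Cc1csc2nc(-c3ccc(Br)cc3)cn12)N/N=C/c1ccc(Cl)cc1Cl` has not yet been measured. It differs from compound 3 in one place: 2,4-dichlorophenyl in place of 2,6-dimethoxyphenyl on a carbon with a double bond to nitrogen. Among the measured compounds shown here, no measured step places chlorine on this ring, so the known steps bear on it only indirectly. For the measured compounds named here, the step from compound 1 to compound 3 shows that putting 2,6-dimethoxyphenyl in place of phenyl left the number within the scatter, whereas the one clearly lower number belongs to compound 2, which carries the hydroxy. Compound 4 carries no hydroxy, so the step of a 1.4-fold lower number from compound 3 to compound 4 (0.14 log units; within the scatter) is expected to stay within the scatter. Compound 4 is therefore estimated to give about 10000 nM, within a range from 4000 nM to 25000 nM.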

Compound 4, concentration for 50% growth inhibition: 28200 nM
Compound 4: middle estimate off by 2.8-fold (0.45 log units), on the low side; measured number above the stated range.
By their numbers in this assay, from the lowest: compound 2; then compounds 1 and 3 (each within the scatter of the next); then compound 4.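

On the carbon with a double bond to nitrogen, this assay now shows a change from phenyl that moves the number beyond the scatter: 2,4-dichlorophenyl gives a 2.3-fold higher number from compound 1 to compound 4 (0.36 log units; beyond the scatter) whereas 2,6-dimethoxyphenyl in the same place had stayed within the scatter of phenyl. The two substituted rings that carry no hydroxy also separate from each other, with a 2.0-fold higher number from compound 3 to compound 4 (0.31 log units; beyond the scatter) as the step, so the absence of a hydroxy does not by itself fix the number at this position. Among the compounds shown here, the largest step in the set, a 13-fold higher number from compound 2 to compound 4 (1.13 log units; beyond the scatter) at this same place, widens the span reached by changing this one group and leaves compound 2, with its 2-hydroxyphenyl, as the only compound clearly lower than all the others.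

Still open is whether the lower number of compound 2 depends on the free hydroxy, as none of these compounds has a 2-methoxyphenyl, an aminophenyl or a carboxyphenyl at this place, and whether a single chlorine would behave as the pair does. No evidence at hand bears on what lies behind these differences.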